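The source may report more compounds than this note shows. Statements on the series, on what has been measured and on what is new or still open speak of the compounds shown alone.

Measured so far:
compound 1 `Nc1sc2c(c1-c1nc3ccccc3s1)CCCC2`: 253 ug/mL
compound 2 `Nc1sc2c(c1-c1nc3cc(Cl)ccc3s1)CCCC2`: 43.5 ug/mL
compound 3 `Clc1ccccc1/C=N/c1sc2c(c1-c1nc3ccccc3s1)CCC2`: 123 ug/mL

All three numbers come from an ADME assay on cells (Rhabdomyosarcoma cell, Homo sapiens) for cytotoxicity, read by MTT assay, with a stated time of 72 h; on this read-out higher numbers stand for lower toxicity in this test and lower numbers for higher toxicity in this test. Compound 2 differs from compound 1 by chloro in place of hydrogen on an aromatic carbon, and that single change made the step of a 5.8-fold lower number from compound 1 to compound 2 (0.76 log units; beyond the scatter). Compound 3 is built on a different core; the difference between the two cores is not broken down here, and its number stands between those of compound 1 and compound 2.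

Compound 4 `Clc1ccc(/C=N/c2sc3c(c2-c2nc4ccccc4s2)CCC3)c(Cl)c1` is not yet measured. It differs from compound 3 by chloro in place of hydrogen on an aromatic carbon. This is the same kind of change as that from compound 1 to compound 2, but the surroundings differ: in compound 2 the chloro enters a ring that is part of a fused or bridged system of two rings, meta to a fused ring and para to a fused ring, whereas in compound 4 it enters a ring of carbon only, meta to a chloro group and para to a large group.

The expectation for compound 4 rests on the step of a 5.8-fold lower number from compound 1 to compound 2 (0.76 log units; beyond the scatter). Going by the values given here, a smaller lowering is expected for compound 4, a 2.5-fold lower number from compound 3 to compound 4 (0.39 log units; beyond the scatter), because a 5.8-fold lower number from compound 1 to compound 2 (0.76 log units; beyond the scatter) is the single precedent and sits in a different setting. Compound 4 is therefore estimated at 50 ug/mL, between 20 ug/mL and 120 ug/mL.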

Compound 4, half-maximal cytotoxic concentration: 160 ug/mL
The estimate for compound 4 lay 3.2-fold (0.51 log units) below the measured number, and the stated range ends below it.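

In this assay, going from the 2-chlorophenyl to the 2,4-dichlorophenyl group gave a 1.3-fold higher number from compound 3 to compound 4 (0.11 log units; within the scatter), so this measurement cannot tell compound 3 and compound 4 apart. The same kind of change therefore did not carry over from one core to the other: the same change on two cores in this assay, a 5.8-fold lower number (0.76 log units; beyond the scatter) from compound 1 to compound 2 and a 1.3-fold higher number (0.11 log units; within the scatter) from compound 3 to compound 4, 7.6-fold (0.88 log units) apart, beyond the scatter of two such steps. This shows that the result of putting chloro in place of hydrogen on an aromatic carbon cannot simply be copied across this series, but it does not show why: the two steps differ both in the core and in the ring that receives the chloro, and each rests on a single pair of compounds.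

The compounds shown leave open how a fluoro or a methoxy group would read at the same place on the ring of carbon only. Also open, from the compounds shown here alone, is what a chloro would do on the fused ring system of compound 3, in the same place as in compound 2, a comparison that would separate the effect of the core from that of the site.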